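The source may report more compounds than this note shows. Statements on the series, on what has been measured and on what is new or still open speak of the compounds shown alone.

Compound 3 `COc1ccc2c(c1)NC(=O)CN2c1nc(N2CCCC2)nc2ccccc12` gives 33.2 nM in a functional assay on KB cells (Homo sapiens) for inhibition, read by sulforhodamine B assay, with a stated time of 48 h (on this read-out higher numbers stand for weaker inhibition of growth and lower numbers for stronger inhibition of growth), which places it second highest of the three numbers in hand. Compound 1 `COc1ccc2c(c1)NC(=O)CN2c1nc(Nc2ccc(C#N)cc2)nc2ccccc12` gives 5.39 nM, and the step of a 6.2-fold higher number from compound 1 to compound 3 (0.79 log units; beyond the scatter) lies beyond the scatter. Compound 2 `COc1ccc2c(c1)NC(=O)CN2c1nc(COCCCC(=O)NO)nc2ccccc12` gives 307 nM, and the step of a 9.2-fold lower number from compound 2 to compound 3 (0.97 log units; beyond the scatter) also lies beyond the scatter. Compound 4 `CCOc1nc(N2CC(=O)Nc3cc(OC)ccc32)c2ccccc2n1` carries ethoxy in place of pyrrolidin-1-yl on an aromatic carbon. Both measured steps alter the same aromatic carbon, and each moved the number by a modest to large amount, so a further change there is unlikely to be neutral. Within the data shown here, no measured compound carries an ethoxy group at that carbon, so the direction has no direct precedent. A modest weakening is expected, a 2.4-fold higher number from compound 3 to compound 4 (0.38 log units; beyond the scatter). Compound 4 is therefore estimated at 80 nM, within 20 nM to 400 nM.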

Compound 4, concentration for 50% growth inhibition: 11.6 nM
Estimate against measurement, compound 4: 6.9-fold (0.84 log units) above; the whole stated range lies above it.
By their numbers in this assay, from the lowest: compound 1; then compound 4; then compound 3; then compound 2.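

At this carbon between two ring nitrogen atoms, the smaller, ringless ethoxy outperforms pyrrolidin-1-yl, with a 2.9-fold lower number from compound 3 to compound 4 (0.46 log units; beyond the scatter). Ethoxy also far outperforms (3-(hydroxycarbamoyl)propoxy)methyl, with a 26-fold lower number from compound 2 to compound 4 (1.42 log units; beyond the scatter), but does not match (4-cyanophenyl)amino, with a 2.2-fold higher number from compound 1 to compound 4 (0.33 log units; beyond the scatter), so a group with no ring or amine nitrogen can come within a modest step of the lowest number in the series. Nothing available explains these differences. Still open, on these data alone, is whether methoxy, a longer propoxy chain or a simple dimethylamino group would follow ethoxy or pyrrolidin-1-yl. Ethoxy alone does not separate the loss of the ring from the exchange of the linking nitrogen for oxygen.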